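A few compounds are considered here, and "the series" means these few. Any claim that something is new, unique, unknown or untested is made for them only; others in the source may bear on it.

Three compounds share one core and differ only in the group on a double-bonded chain carbon bound to a double-bonded chain carbon. Compound 1 `CC1=C(/C=C/C(=O)/C=C/c2ccc(Br)cc2)C(C)(C)CCC1` gives 10400 nM in a functional assay on IMR-32 cells (Homo sapiens) for cytotoxicity, read by sulforhodamine B assay, with a stated time of 48 h; a higher number here means a weaker inhibitor, a lower number a stronger inhibitor. Compound 2 `CC1=C(/C=C/C(=O)/C=C/c2ccc(C)cc2)C(C)(C)CCC1` gives 19200 nM in this assay. Compound 3 `CC1=C(/C=C/C(=O)/C=C/c2cccnc2)C(C)(C)CCC1` gives 25300 nM in this assay, the highest of the three numbers, with a 2.4-fold higher number from compound 1 to compound 3 (0.39 log units; beyond the scatter) beyond the scatter but a 1.3-fold higher number from compound 2 to compound 3 (0.12 log units; within the scatter) within it. Compound 4 `CC1=C(/C=C/C(=O)/C=C/c2ccoc2)C(C)(C)CCC1` differs from compound 3 by furan-3-yl in place of pyridin-3-yl on a double-bonded chain carbon bound to a double-bonded chain carbon. Going by the values given here, the steps that bear on exchanging this ring were modest at most, so little movement is expected for compound 4, with a 1.0-fold lower number from compound 3 to compound 4 (0.01 log units; within the scatter) expected to stay within the scatter. The estimate for compound 4 is 25000 nM, with a range from 12000 nM to 50000 nM.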

Compound 4, half-maximal inhibitory concentration: 56800 nM
Beside the measured number, compound 4's estimate is 2.3-fold (0.36 log units) below it; measured number above the stated range.
By their numbers in this assay, from the lowest: compounds 1, 2 and 3 (each within the scatter of the next, the first and the last beyond it); then compound 4.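

In this assay, this position proves sensitive to a ring exchange: furan-3-yl in place of pyridin-3-yl gives a 2.2-fold higher number from compound 3 to compound 4 (0.35 log units; beyond the scatter) as a step beyond the scatter, so a heteroaromatic ring is not freely interchangeable here. The gap grows against the substituted phenyl rings, with a 3.0-fold higher number from compound 2 to compound 4 (0.47 log units; beyond the scatter) and a 5.5-fold higher number from compound 1 to compound 4 (0.74 log units; beyond the scatter) making compound 4 the weakest of the four. No evidence explains this weakening. As far as these compounds go, compound 4 changes ring size and hetero atom together, so their separate contributions remain open. From the compounds shown here alone, how a thiophen-3-yl ring or a plain phenyl ring would read at this position also remains open.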